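The source may hold more compounds than are shown below. What is called first, only, known or untested is meant among the compounds shown, and "the series" means these compounds.

Measured so far:
- compound 1 `Clc1cccc(Nc2ncnc3ccc(NCc4c[nH]c5ccccc45)cc23)c1`: 5260 nM
- compound 2 `O=C(/C=C/c1cccnc1)Nc1ccc2ncnc(Nc3cccc(Cl)c3)c2c1`: 9120 nM
- compound 3 `O=C(/C=C/c1ncc2ccccc2n1)Nc1ccc2ncnc(Nc3cccc(Cl)c3)c2c1`: 7790 nM

All three were tested in a functional assay on HepG2 cells (Homo sapiens) for antiproliferative activity, read by MTT assay, with a stated time of 48 h; a higher number here means a weaker inhibitor, a lower number a stronger inhibitor. Compound 3 has the second highest of the three numbers; its nearest neighbour is compound 2, and compound 1 is furthest away, yet both gaps lie within the scatter, so the three compounds cannot be told apart on these numbers.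

Compound 4 `O=C(/C=C/c1c[nH]c2ccccc12)Nc1ccc2ncnc(Nc3cccc(Cl)c3)c2c1` has not yet been measured. It differs from compound 3 in one place: 1H-indol-3-yl in place of quinazolin-2-yl on a double-bonded chain carbon bound to a double-bonded chain carbon

For the measured compounds named here, one measured step bears on this change, the exchange of one ring system for another on the same chain carbon: a 1.2-fold lower number from compound 2 to compound 3 (0.07 log units; within the scatter). That swap moved the number by less than the scatter. Compound 1 also carries a 1H-indol-3-yl group and sits within the scatter of compound 3. From this, the change to compound 4 is expected to give at most a small step in this assay, a 1.3-fold lower number from compound 3 to compound 4 (0.11 log units; within the scatter), with no direction that can be trusted. Compound 4 is therefore estimated at 6000 nM, between 2500 nM and 14000 nM.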

Compound 4, half-maximal inhibitory concentration: 7020 nM
Estimate against measurement, compound 4: 1.2-fold (0.07 log units) below; low and high end bracket the measured number.
By their numbers in this assay, from the lowest: compounds 1, 4, 3 and 2 (each within the scatter of the next).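

In this assay, putting 1H-indol-3-yl on this chain carbon gives a 1.1-fold lower number from compound 3 to compound 4 (0.05 log units; within the scatter) and, against the other earlier group, a 1.3-fold lower number from compound 2 to compound 4 (0.11 log units; within the scatter). For the compounds shown here, the earlier pair showed only that one six-membered-ring group could replace another, whereas 1H-indol-3-yl brings a five-membered aromatic ring and a hydrogen-bond donor, and quinazolin-2-yl has neither, yet the number stays within the scatter, so these three ring groups cannot be told apart at this position. No measurement at hand offers a reason for this sameness.

All three groups are aromatic ring systems, so the compounds shown leave open whether this position responds to anything of a different kind. An amine or a carboxylic acid on this chain carbon might still move the number beyond the scatter.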